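Swapping the alkyne cap: from pyridazine to benzofuran

The source may hold more compounds than are shown below. What is called first, only, known or untested is meant among the compounds shown, and "the series" means these compounds.

Compound 1, `CNC(=O)[C@@]12C[C@@H]1[C@@H](n1cnc3c(NC)nc(C#Cc4cccc(C(F)(F)F)c4)nc31)[C@H](O)[C@@H]2O`: in an assay on CHO cells for displacement of a labelled ligand from adenosine receptor A3 (Homo sapiens), read by scintillation counting, with a stated time of 60 min (a higher number here means a weaker inhibitor, a lower number a stronger inhibitor), compound 1 gives 3.39 nM.
Compound 2, `CNC(=O)[C@@]12C[C@@H]1[C@@H](n1cnc3c(NC)nc(C#Cc4cccnn4)nc31)[C@H](O)[C@@H]2O`: in this assay compound 2 gives 3.53 nM.

Among the two numbers measured, compound 2 sits alongside compound 1, since the step of a 1.0-fold higher number from compound 1 to compound 2 (0.02 log units; within the scatter) lies within the scatter. Compound 3, `CNC(=O)[C@@]12C[C@@H]1[C@@H](n1cnc3c(NC)nc(C#Cc4cc5ccccc5o4)nc31)[C@H](O)[C@@H]2O`, differs from compound 2 by 1-benzofuran-2-yl in place of pyridazin-3-yl on a triple-bonded carbon. Among the measured compounds shown here, the only measured step touching this position is a 1.0-fold higher number from compound 1 to compound 2 (0.02 log units; within the scatter), where replacing the group on the triple-bonded carbon left the number essentially unchanged. A step of similar size is therefore expected from compound 2 to compound 3, a 1.1-fold higher number from compound 2 to compound 3 (0.05 log units; within the scatter), none beyond the scatter. Compound 3 is estimated to give about 4 nM, between 1.5 nM and 12 nM.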

Compound 3, inhibition constant: 1.62 nM
Estimate against measurement, compound 3: 2.5-fold (0.39 log units) above; low and high end bracket the measured number.
By their numbers in this assay, from the lowest: compound 3; then compounds 1 and 2 (each within the scatter of the next).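

In this assay this position proves sensitive to the group it carries: 1-benzofuran-2-yl brings a 2.2-fold lower number from compound 2 to compound 3 (0.34 log units; beyond the scatter) and also a 2.1-fold lower number from compound 1 to compound 3 (0.32 log units; beyond the scatter) even though pyridazin-3-yl and 3-(trifluoromethyl)phenyl could not be told apart. Both steps are modest, but they show that a change on the triple-bonded carbon can move the number beyond the scatter.

On these data alone, whether the benzofuran oxygen or its second ring matters stays open, as does what an amine or a carboxylic acid would do in this place. Nothing measured here gives a reason for the lower number.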